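Trifluoromethyl for fluoro on the pendant phenyl ring

The compounds below may be only part of what the source reports. "The series", "measured", "known", "first", "only" and "open" are said of these compounds alone.

Compound 1 `COc1cc2c(Oc3ccc(NC(=O)c4cc(-c5ccccc5)ccn4)cc3F)ccnc2cc1OCCCN1CCN(C)CC1`: 150 nM
Compound 2 `COc1cc2c(Oc3ccc(NC(=O)c4cc(-c5ccc(F)cc5)ccn4)cc3F)ccnc2cc1OCCCN1CCCCC1`: 1240 nM

Of the compounds shown here, two have been measured in a functional assay on MKN-45 cells (Homo sapiens) for cytotoxicity, read by MTT assay, with a stated time of 72 h; on this read-out higher numbers stand for weaker inhibition and lower numbers for stronger inhibition. Compound 1 `COc1cc2c(Oc3ccc(NC(=O)c4cc(-c5ccccc5)ccn4)cc3F)ccnc2cc1OCCCN1CCN(C)CC1` gives 150 nM in this assay, and compound 2 `COc1cc2c(Oc3ccc(NC(=O)c4cc(-c5ccc(F)cc5)ccn4)cc3F)ccnc2cc1OCCCN1CCCCC1` gives 1240 nM. Compound 2 therefore stands at the higher, weaker end of the two numbers, and the gap between the two values is well beyond the usual scatter of the measurement. Within the data shown here, the two compounds differ in more than one place, so no single step joins them and nothing more than the two values themselves can be read from the pair.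

Compound 3 `COc1cc2c(Oc3ccc(NC(=O)c4cc(-c5ccc(C(F)(F)F)cc5)ccn4)cc3F)ccnc2cc1OCCCN1CCCCC1` has not yet been measured. It differs from compound 2 by one change, (trifluoromethyl in place of fluoro on an aromatic carbon), trifluoromethyl in place of fluoro on an aromatic carbon. No measured step of this kind exists among these compounds, so the size of the change in this assay cannot be anchored to a precedent. The expected step from compound 2 to compound 3 is a 1.2-fold higher number from compound 2 to compound 3 (0.08 log units; within the scatter), a modest change that may not exceed the scatter. Compound 3 is estimated at 1500 nM, within a range of 400 nM to 6000 nM.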

Compound 3, half-maximal inhibitory concentration: 870 nM
The estimate for compound 3 lay 1.7-fold (0.24 log units) above the measured number; the range from low to high includes it.
By their numbers in this assay, from the lowest: compound 1; then compounds 3 and 2 (each within the scatter of the next).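

In this assay, putting trifluoromethyl in place of fluoro, that is, going from 4-fluorophenyl to 4-(trifluoromethyl)phenyl, gives the first step measured at this position: a 1.4-fold lower number from compound 2 to compound 3 (0.15 log units; within the scatter). The earlier compounds shown here offered no such reading, since they differ in more than one place; this pair shows that, with everything else in the structure held the same, the heavy atoms that trifluoromethyl adds over fluoro leave the two numbers indistinguishable in this assay. No measurement shown here bears on why the two numbers lie so close together.

What the compounds shown leave open is whether this position stays as undemanding with groups of a different kind, such as a methoxy group, an amine or a carboxylic acid, in place of fluoro or trifluoromethyl on the same aromatic carbon. Among these compounds, it also remains open whether the same exchange would give a step of similar size on a compound carrying the side chain of compound 1 instead of the one shared by compound 2 and compound 3.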